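The source may hold more compounds than are shown below. What is called first, only, known or untested is meant among the compounds shown, and "the series" means these compounds.

Working notes on the series, exposure in an ADME assay on the whole organism for pharmacokinetics, with Mus musculus as the target, at a dose of 50 mg/kg by the oral route; on this read-out higher numbers stand for higher exposure at the dose given and lower numbers for lower exposure.

Of the compounds shown here, two of the shared core have been measured. Compound 1 `O=C(NCc1ccc(N2CCC(c3ccc(OC(F)(F)F)cc3)CC2)cc1)c1cc([N+](=O)[O-])cc([N+](=O)[O-])c1` gives 672 nM and stands highest of the two numbers. Compound 2 `O=C(NCc1ccc(N2CCN(c3ccc(F)cc3)CC2)cc1)c1cc([N+](=O)[O-])cc([N+](=O)[O-])c1` gives 31.3 nM, a markedly lower number; the two compounds differ in more than one place, so the gap between them is read only as what the two values show, not as a step tied to a single change.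

The step under consideration leads from compound 1 to compound 3 `O=C(NCc1ccc(N2CCC(C(F)(F)F)CC2)cc1)c1cc([N+](=O)[O-])cc([N+](=O)[O-])c1`. The change is trifluoromethyl in place of 4-(trifluoromethoxy)phenyl on a saturated ring carbon. Among the measured compounds shown here, no measured pair in the set isolates this change, so the step from compound 1 is not known from precedent. The expectation is a modest drop for compound 3 in this assay, a step of a 1.9-fold lower number from compound 1 to compound 3 (0.28 log units; within the scatter) that may well sit within the usual scatter, with the number of compound 1 as the anchor. Compound 3 is therefore estimated at 350 nM in this assay, within a range of 80 nM to 1500 nM.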

Compound 3, maximal plasma concentration: 3800 nM
For compound 3 the middle estimate is 11-fold (1.04 log units) below the measured one, and the stated range ends below it.
By their numbers in this assay, from the lowest: compound 2; then compound 1; then compound 3.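

Among the compounds shown here, at the saturated ring carbon, three ring bonds from the ring nitrogen, the 4-(trifluoromethoxy)phenyl is not required for exposure in this assay: trifluoromethyl in its place gives a 5.7-fold higher number from compound 1 to compound 3 (0.75 log units; beyond the scatter) and sets the highest number so far. This position therefore tolerates the loss of the six-membered aromatic ring of carbon only, and the group that enters has fewer heavy atoms than the group that leaves, without any loss of exposure on this read-out. For the compounds shown here, this is the first single-place step in the set, but it rests on one pair, and no measurement at hand accounts for the direction or size of the step.

On these data alone, it remains open whether the higher number belongs to trifluoromethyl itself or simply to the absence of the aromatic ring, a question that a methyl group, a hydroxyl group or an unsubstituted ring carbon at the same place would help to separate. As far as these compounds go, it is also open whether an amine, a nitrile or a longer fluorinated chain at this carbon would hold the number of compound 3, 3800 nM, in this assay.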